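This account rests on a few compounds, and the source may have more. Where it says the series, first, only, none or still open, it means among the compounds named here.

Working notes on the series. Of the compounds shown here, two have been measured in a functional assay on HT-1080 cells (Homo sapiens) for antiproliferative activity, read by sulforhodamine B assay, with a stated time of 48 h; on this read-out higher numbers stand for weaker inhibition and lower numbers for stronger inhibition: compound 1 `CCCC(=O)Nc1ccc(S(=O)(=O)Oc2ccccc2C(C)C)cc1` gives 950 nM, and compound 2 `CCNC(=O)Nc1ccc(S(=O)(=O)Oc2ccccc2C(C)C)cc1` gives 250 nM. Among the compounds with values here, the one measured step, a 3.8-fold lower number from compound 1 to compound 2 (0.58 log units; beyond the scatter), is the only change recorded so far, and on these two numbers compound 2 stands with the lower one, the gap to compound 1 lying beyond the scatter.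

Compound 3 `CCCNC(=O)Nc1ccc(S(=O)(=O)Oc2ccccc2C(C)C)cc1` is not yet measured. It differs from compound 2 by methyl in place of hydrogen on a saturated chain carbon, two bonds along the chain from an amide-type nitrogen, that is, ethylamino becoming propylamino. Within the data shown here, no measured step covers this change: the step from compound 1 to compound 2 swaps an alkyl for an alkylamino on the carbonyl carbon and does not speak to lengthening the chain on the nitrogen. With nothing to lean on, no step beyond the scatter is expected from compound 2 to compound 3, so no change at the digits printed from compound 2 to compound 3 (within the scatter) is estimated. Compound 3 is therefore expected to give 250 nM in this assay, within the range 100 nM to 650 nM.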

Compound 3, half-maximal inhibitory concentration: 680 nM
Beside the measured number, compound 3's estimate is 2.7-fold (0.43 log units) below it, and the stated range ends below it.
By their numbers in this assay, from the lowest: compound 2; then compounds 3 and 1 (each within the scatter of the next).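

In this assay the ethylamino to propylamino change, methyl in place of hydrogen on a saturated chain carbon, two bonds along the chain from an amide-type nitrogen, gives a 2.7-fold higher number from compound 2 to compound 3 (0.43 log units; beyond the scatter), so this chain position responds to one added carbon and ethylamino is the better of the two lengths here. Propylamino in place of propyl on the carbonyl carbon gives a 1.4-fold lower number from compound 1 to compound 3 (0.15 log units; within the scatter), so the lower number of compound 2 does not carry over to the longer chain. Nothing available explains why this added methyl raises the number.

On these data alone, whether methylamino would give a still lower number, or butylamino a higher one, remains open. Also open, as far as these compounds go, is how a branched isopropylamino group or a cyclopropylamino group would compare with ethylamino at this position.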